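Swapping the distal aryl of compound 3 for an acrylate ester

The compounds below may be only part of what the source reports. "The series", "measured", "known", "first", "only" and "open" are said of these compounds alone.

Of the compounds shown here, three built on one shared core have been measured in an assay on isolated protein with Bile acid receptor (Homo sapiens) as the target; a lower number here means that less compound is needed, a higher number that more compound is needed for the effect. Compound 1 `COC(=O)/C=C/c1cccc(N(Cc2ccc(/C=C/c3ccccc3F)cc2)C(=O)NC(C)C)c1` gives 431 nM. Compound 2 `COC(=O)/C=C/c1cccc(N(Cc2ccc(/C=C/c3c(C)cc(C)cc3C)cc2)C(=O)NC(C)C)c1` gives 431 nM. Compound 3 `COC(=O)/C=C/c1cccc(N(Cc2ccc(-c3ccc(C)cc3)cc2)C(=O)NC(C)C)c1` gives 449 nM, a number that sits within the scatter of the other two, so no order among them can be read. Compound 4 `COC(=O)/C=C/c1cccc(N(Cc2ccc(/C=C/C(=O)OC(C)(C)C)cc2)C(=O)NC(C)C)c1` differs from compound 3 by 2-(tert-butoxycarbonyl)ethenyl in place of 4-methylphenyl on an aromatic carbon. Within the data shown here, the steps that bear on this position are a 1.0-fold higher number from compound 1 to compound 3 (0.02 log units; within the scatter) and a 1.0-fold higher number from compound 2 to compound 3 (0.02 log units; within the scatter): three different groups at the same place gave numbers that do not separate. Among the measured compounds shown here, no measured step tests an ester there, so the expectation rests on this tolerance alone. For compound 4 the step of a 1.2-fold higher number from compound 3 to compound 4 (0.06 log units; within the scatter) is expected, giving an estimate of 520 nM with a range from 180 nM to 1600 nM.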

Compound 4, half-maximal effective concentration: 212 nM
Estimate against measurement, compound 4: 2.5-fold (0.39 log units) above; low and high end bracket the measured number.
By their numbers in this assay, from the lowest: compound 4; then compounds 1, 2 and 3 (each within the scatter of the next).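

The group on this aromatic carbon can shift the number after all: the ring-free 2-(tert-butoxycarbonyl)ethenyl gives a 2.1-fold lower number from compound 3 to compound 4 (0.33 log units; beyond the scatter) and also a 2.0-fold lower number from compound 2 to compound 4 (0.31 log units; beyond the scatter) and a 2.0-fold lower number from compound 1 to compound 4 (0.31 log units; beyond the scatter) in the comparisons with the two aryl-ended ethenyl compounds. These steps are modest but beyond the scatter, whereas the three groups ending in an aromatic ring did not separate from one another. No measurement here accounts for the lower number.

On these data alone, whether the ester itself matters remains open. A carboxylic acid or an amide in its place would test this, and a methyl ester would test the role of the tert-butyl group.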